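Chlorinated benzocyclobutene analogue: expected binding to serotonin 1B receptor

The source may hold more compounds than are shown below. What is called first, only, known or untested is meant among the compounds shown, and "the series" means these compounds.

Measured compounds:
compound 1 `c1ccc2c(c1)CC2CCCN1CCN(c2cccc3c2OCCO3)CC1`, 646 nM
compound 2 `c1ccc2c(c1)CC2CCCCN1CCN(c2cccc3c2OCCO3)CC1`, 631 nM
compound 3 `c1ccc2c(c1)CCC2CCCN1CCN(c2cccc3c2OCCO3)CC1`, 204 nM

In an assay on isolated protein for binding affinity to 5-hydroxytryptamine receptor 1B (Rattus norvegicus) (on this read-out lower numbers stand for stronger inhibition and higher numbers for weaker inhibition), compound 1 gives the highest number of the three; compound 2 sits within the scatter of it, while compound 3 gives a lower number. Compound 4 `Clc1cccc2c1CC2CCN1CCN(c2cccc3c2OCCO3)CC1` arises from compound 1 by a group of 9 heavy atoms (8 carbon, 1 chlorine; one four-membered non-aromatic ring of carbon only, one six-membered aromatic ring of carbon only) in place of a group of 9 heavy atoms (9 carbon; one four-membered non-aromatic ring of carbon only, one six-membered aromatic ring of carbon only), on a saturated chain carbon, two bonds along the chain from an amine nitrogen in a ring. Neither measured step bears directly on this change: the chain lengthening a 1.0-fold lower number from compound 1 to compound 2 (0.01 log units; within the scatter) stayed within the scatter, and the ring change a 3.2-fold lower number from compound 1 to compound 3 (0.50 log units; beyond the scatter) was modest, but neither adds a chlorine nor shortens the chain. Without a step of its own kind to rest on, no step beyond the scatter is expected in this assay, a 1.1-fold lower number from compound 1 to compound 4 (0.03 log units; within the scatter). Compound 4 is therefore estimated at 600 nM, with a range from 180 nM to 2000 nM.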

Compound 4, inhibition constant: 708 nM
For compound 4 the middle estimate is 1.2-fold (0.07 log units) below the measured one; the measured number falls inside the stated range.
By their numbers in this assay, from the lowest: compound 3; then compounds 2, 1 and 4 (each within the scatter of the next).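

In this assay, the group carrying chlorine, set on a saturated chain carbon two bonds along the chain from an amine nitrogen in a ring, gives a 1.1-fold higher number from compound 1 to compound 4 (0.04 log units; within the scatter) and so stays within the scatter. Chlorine and the shift in chain attachment thus arrive together here without moving the number beyond the scatter. No available evidence accounts for this result.

The compounds shown leave open what chlorine does apart from the chain change. They also leave open whether fluorine or a methoxy group in its place, or chlorine on the five-membered ring group of compound 3, would read the same.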